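The source may report more compounds than this note shows. Statements on the series, on what has been measured and on what is new or still open speak of the compounds shown alone.

Values so far in a functional assay on MCF7 cells (Homo sapiens) for antiproliferative activity, with a stated time of 5 days (a higher number here means a weaker inhibitor, a lower number a stronger inhibitor), for the series

- Compound 1 `COc1ccc(-c2[nH]c3ccc(OC)cc3c2C=O)cc1` gives 180 nM
- Compound 2 `COc1ccc(-c2[nH]c3ccc(F)cc3c2C=O)cc1` gives 240 nM
- Compound 3 `COc1ccc(-c2[nH]c3ccc(C)cc3c2C=O)cc1` gives 140 nM

Compound 3 lies within the scatter of both other compounds, so the three values give no order (a 1.3-fold lower number from compound 1 to compound 3 (0.11 log units; within the scatter); a 1.7-fold lower number from compound 2 to compound 3 (0.23 log units; within the scatter)). The remaining step is of the same kind (a 1.3-fold higher number from compound 1 to compound 2 (0.12 log units; within the scatter)).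

Next in the series is compound 4 `COc1ccc(-c2[nH]c3ccc(C(C)C)cc3c2C=O)cc1` with isopropyl in place of methyl on an aromatic carbon. All three measured steps exchange the group on this same carbon, and methoxy, fluoro and methyl show no step beyond the scatter in this assay for these compounds. Among the measured compounds shown here, no measured compound carries isopropyl there, so the expectation is an extrapolation and its range is kept wide. No step beyond the scatter is expected, in either direction.

The estimated step is a 1.4-fold higher number from compound 3 to compound 4 (0.15 log units; within the scatter) in the middle of that range. The expected value for compound 4 is 200 nM with an estimated range from 70 nM to 600 nM as its bounds.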

Compound 4, half-maximal inhibitory concentration: 97 nM
Estimate against measurement, compound 4: 2.1-fold (0.31 log units) above; the measured number falls inside the stated range.
By their numbers in this assay, from the lowest: compounds 4, 3, 1 and 2 (each within the scatter of the next, the first and the last beyond it).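

In this assay, this aromatic carbon takes isopropyl, the group with more heavy atoms, without a step beyond the scatter from methyl (a 1.4-fold lower number from compound 3 to compound 4 (0.16 log units; within the scatter)) or from methoxy (a 1.9-fold lower number from compound 1 to compound 4 (0.27 log units; within the scatter)). Among the compounds shown here, the exchange of fluoro for isopropyl gives the first step beyond the scatter at this position, though a modest one (a 2.5-fold lower number from compound 2 to compound 4 (0.39 log units; beyond the scatter)), so the groups here can now be told apart at the two ends of the series. No measured evidence bears on the reason for this step.

Open, from the compounds shown here alone, is whether tert-butyl, a longer chain, an amine or a carboxylic acid on this carbon would stay within the scatter of compound 4 or move beyond it. Also open, going by these compounds, is whether the step from fluoro to isopropyl holds with a nitrile in place of the aldehyde of the shared core.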